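A few compounds are considered here, and "the series" means these few. Any claim that something is new, unique, unknown or untested is made for them only; others in the source may bear on it.

Of the compounds shown here, two from this study have so far been measured in an ADME assay on microsomes from liver (Homo sapiens) for metabolic stability, with a stated time of 30 min, tested at 2 uM, in the presence of a further agent that is not named here; a lower number here means that less of the compound is left, a higher number that more of the compound is left. Compound 1 `CC[C@@H]1c2cn[nH]c2C(=O)[C@H](CC)N1S(=O)(=O)c1ccc(Cl)cc1` gives 65% in this assay. Compound 2 `CC1(C)C(=O)c2[nH]ncc2C(C2CC2)N1S(=O)(=O)c1ccc(C(F)(F)F)cc1` gives 67% in this assay. Compound 1 therefore carries the lower of the two numbers, but the gap to compound 2 is within the usual scatter of repeated measurements, so the two cannot be told apart on these data.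

Compound 3 `CC[C@@H]1C(=O)c2[nH]ncc2[C@H](CC)N1S(=O)(=O)c1ccc(Cl)cc1` has not yet been measured in this assay. It differs from compound 1 as follows: the two compounds have the same atoms and bonds and differ only in configuration as drawn: 2 of 2 stereo elements differ (all stereocentres are inverted: mirror images); a stereocentre at a saturated ring carbon is drawn S in compound 1 and R in compound 3; a stereocentre at a saturated ring carbon is drawn R in compound 1 and S in compound 3. In words, the two compounds have the same atoms and bonds and differ only in configuration as drawn: all stereocentres are inverted, so compound 3 is the mirror image of compound 1.

Among the measured compounds shown here, no pair of measured compounds shows what such an inversion does in this assay, so there is no measured step to lean on. The expected step is a number 2 percentage points lower from compound 1 to compound 3 (within the scatter), which is estimated to fall within the scatter, in no clear direction. For compound 3 in this assay a value of about 63% is expected, with a range from 40% to 85%.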

Compound 3, percent of the compound remaining: 77%
The estimate for compound 3 lay 14 percentage points below the measured number, and the stated range covers the measured number.
By their numbers in this assay, from the lowest: compounds 1, 2 and 3 (each within the scatter of the next, the first and the last beyond it).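

In this assay, inverting both stereocentres gives a number 12 percentage points higher from compound 1 to compound 3 (beyond the scatter) and so shows that the spatial arrangement of the groups can shift this read-out on its own. The earlier compounds shown here could not show this, as no measured pair isolated a single change, whereas here the atoms and bonds stay identical and only the handedness of the molecule changes. The step can be assigned to configuration rather than to any change of group, because nothing else separates the pair: the fact that compounds 1 and 3 differ only in the configuration as drawn.

Both stereocentres change together in this pair, so the compounds shown leave open whether one of them accounts for the step or both contribute, and they give no reason for the shift. They also leave open whether the same inversion would produce a similar step with a different group on the shared core, such as a propyl chain or an amine in place of an ethyl group.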